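The source may report more compounds than this note shows. Statements on the series, on what has been measured and on what is new or still open speak of the compounds shown alone.

Among the compounds with values here, compound 1 `COC(=O)C(=O)CNC1=CS(=O)(=O)O[C@@]12[C@@H](CO[Si](C)(C)C(C)(C)C)O[C@@H](n1cc(C)c(=O)n(C)c1=O)[C@@H]2O[Si](C)(C)C(C)(C)C` is one of three compounds measured in a functional assay on CCRF-CEM cells (Homo sapiens) (a higher number here means that more compound is tolerated, a lower number that less compound is tolerated), and on those numbers compound 1 stands lowest, giving 5570 nM. Compound 2 `Cc1cn([C@@H]2O[C@H](CO[Si](C)(C)C(C)(C)C)[C@@]3(OS(=O)(=O)C=C3NCCC(=O)O)[C@H]2O[Si](C)(C)C(C)(C)C)c(=O)n(C)c1=O` gives 19400 nM, and compound 3 `Cc1cn([C@@H]2O[C@H](CO[Si](C)(C)C(C)(C)C)[C@@]3(OS(=O)(=O)C=C3NCC(=O)C(=O)N3CCC3)[C@H]2O[Si](C)(C)C(C)(C)C)c(=O)n(C)c1=O` gives 21600 nM. The step of a 3.5-fold higher number from compound 1 to compound 2 (0.54 log units; beyond the scatter) and the step of a 3.9-fold higher number from compound 1 to compound 3 (0.59 log units; beyond the scatter) both raise the number from the starting point of compound 1, whereas a 1.1-fold higher number from compound 2 to compound 3 (0.05 log units; within the scatter) is not a change that can be read as real. Compound 4 `Cc1cn([C@@H]2O[C@H](CO[Si](C)(C)C(C)(C)C)[C@@]3(OS(=O)(=O)C=C3NCC(=O)OCc3ccccc3)[C@H]2O[Si](C)(C)C(C)(C)C)c(=O)n(C)c1=O` differs from compound 1 in one place: benzyloxy in place of methoxycarbonyl on a carbonyl carbon. This alteration touches the same part of the side chain on the shared core that was altered from compound 1 to compound 2 and from compound 1 to compound 3, and both of those alterations moved the number upward beyond the scatter in this assay. The change to compound 4 is therefore expected to move the number in the same direction by a comparable step, a 2.5-fold higher number from compound 1 to compound 4 (0.40 log units; beyond the scatter). Compound 4 is estimated to give 14000 nM in this assay, most likely between 6000 nM and 35000 nM.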

Compound 4, half-maximal cytotoxic concentration: 250000 nM
Beside the measured number, compound 4's estimate is 18-fold (1.25 log units) below it; the whole stated range lies below it.
By their numbers in this assay, from the lowest: compound 1; then compounds 2 and 3 (each within the scatter of the next); then compound 4.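

In this assay, the side chain position on the shared core proves far more sensitive than the earlier modest steps suggested: benzyloxy in place of methoxycarbonyl gives a 45-fold higher number from compound 1 to compound 4 (1.65 log units; beyond the scatter) and so much more compound is tolerated. The gain is not shared by the other side chains, since compound 4 also stands well clear of them, with a 12-fold higher number from compound 3 to compound 4 (1.06 log units; beyond the scatter) and a 13-fold higher number from compound 2 to compound 4 (1.11 log units; beyond the scatter) on top of the first rise, so benzyloxycarbonyl is set apart here from both (azetidin-1-yl)carbonyl and carboxymethyl. Within the data shown here, nothing measured explains why this change moves the number so far.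

The change brings in an aromatic ring and also removes a carbonyl, and these two parts cannot be separated here. Ethoxy or 2-phenylethoxy on the same carbonyl carbon would be needed to tell them apart.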